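Aryl amide variation and cytotoxicity toward THP-1 cells

This account rests on a few compounds, and the source may have more. Where it says the series, first, only, none or still open, it means among the compounds named here.

Measured so far:
compound 1 `Nc1nn(Cc2cn(CC(=O)Nc3ccccc3)nn2)c2nc(-c3ccccc3)cc(C(F)(F)F)c12`, 54.6 ug/mL
compound 2 `COc1ccc(NC(=O)Cn2cc(Cn3nc(N)c4c(C(F)(F)F)cc(-c5ccccc5)nc43)nn2)cc1`, 56.7 ug/mL

In a functional assay on THP-1 cells (Homo sapiens) for cytotoxicity, read by MTT assay, with a stated time of 24 h (on this read-out lower numbers stand for stronger inhibition and higher numbers for weaker inhibition), compound 1 gives 54.6 ug/mL. Compound 2, carrying a methoxy in place of hydrogen on an aromatic carbon, gives 56.7 ug/mL in this assay, and the step of a 1.0-fold higher number from compound 1 to compound 2 (0.02 log units; within the scatter) shows the two values lie within the scatter of each other. Compound 3 `Nc1nn(Cc2cn(CC(=O)Nc3cccc(Cl)c3)nn2)c2nc(-c3ccccc3)cc(C(F)(F)F)c12` is not yet measured. It differs from compound 2 by 3-chlorophenyl in place of 4-methoxyphenyl on an amide-type nitrogen. Going by the values given here, no measured step covers this swap; the one step known, from compound 1 to compound 2, altered the same aryl amide and stayed within the scatter. A step of no more than the scatter is therefore expected for compound 3, a 1.1-fold lower number from compound 2 to compound 3 (0.04 log units; within the scatter). Compound 3 is estimated at 52 ug/mL, within a range from 26 ug/mL to 105 ug/mL.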

Compound 3, half-maximal inhibitory concentration: 37 ug/mL
Compound 3: the middle estimate sits 1.4-fold (0.15 log units) above what was measured; low and high end bracket the measured number.
By their numbers in this assay, from the lowest: compounds 3, 1 and 2 (each within the scatter of the next).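

In this assay the place on the amide-type nitrogen now holds a chlorinated ring as well, and both new steps stay within the scatter (a 1.5-fold lower number from compound 2 to compound 3 (0.19 log units; within the scatter)) and (a 1.5-fold lower number from compound 1 to compound 3 (0.17 log units; within the scatter)). Phenyl, 4-methoxyphenyl and 3-chlorophenyl therefore cannot be told apart at this position, whether the ring carries oxygen or chlorine. Nothing available offers an explanation for this reading. The compounds shown leave open whether an amine or a carboxylic acid on this ring, or a longer chain between the amide and the triazole-bearing core, would move the number beyond the scatter.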